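This account rests on a few compounds, and the source may have more. Where it says the series, first, only, none or still open, it means among the compounds named here.

Measured in an ADME assay on NIH3T3 cells (Mus musculus) for cytotoxicity, read by MTT assay, with a stated time of 72 h; a higher number here means a weaker inhibitor, a lower number a stronger inhibitor:
- compound 1 `COc1ccc(/C=C/C(=O)CC(C)=O)cc1OC`: 18100 nM
- compound 2 `Cc1cc(/C=C/c2ccc(O)c(O)c2)on1`: 26200 nM

In this assay, compound 2 at 26200 nM stands within the usual scatter of compound 1 at 18100 nM. Compound 3 `Cc1cc(/C=C/c2ccc(O)cc2)on1` has not yet been measured. It differs from compound 2 as follows: hydrogen in place of hydroxy on an aromatic carbon, ortho to a hydroxy group. Going by the values given here, no measured pair shows this change, so no step beyond the scatter is expected in this assay. The expected step is a 1.1-fold higher number from compound 2 to compound 3 (0.06 log units; within the scatter). For compound 3 the estimated value is 30000 nM, with an expected range of 12000 nM to 70000 nM.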

Compound 3, half-maximal inhibitory concentration: 88500 nM
Beside the measured number, compound 3's estimate is 3.0-fold (0.47 log units) below it; the measured number lies above the stated range.
By their numbers in this assay, from the lowest: compounds 1 and 2 (each within the scatter of the next); then compound 3.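

In this assay the hydroxy group ortho to a hydroxy group proves to matter: hydrogen in its place gives a 3.4-fold higher number from compound 2 to compound 3 (0.53 log units; beyond the scatter) and so moves toward weaker inhibition, beyond the scatter. Going by these compounds alone, this is the first single change measured, as compound 1 differs from compound 2 in more than one place. Nothing measured here explains the rise. The compounds shown leave open whether an amine or a fluorine atom at this place would keep the number of compound 2 or that of compound 3. They also leave open whether the same change would give a similar step on the core of compound 1.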